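Swapping the Ring on the Amide Carbonyl of Compound 3

The source may report more compounds than this note shows. Statements on the series, on what has been measured and on what is new or still open speak of the compounds shown alone.

Values in a functional assay on LOX IMVI cells (Homo sapiens) for inhibition, read by colorimetric assay and sulforhodamine B assay, with a stated time of 48 h; on this read-out lower numbers stand for stronger inhibition of growth and higher numbers for weaker inhibition of growth:
- compound 1 `CCCCCCCCCCCC[C@@H](O)[C@H]1CC[C@H]([C@H](O)CCCCCCCCCCNC(=O)c2cccs2)O1` gives 1290 nM
- compound 2 `CCCCCCCCCCCC[C@@H](O)[C@H]1CC[C@H]([C@H](O)CCCCCCCCCCNC(=O)c2ccco2)O1` gives 17000 nM
- compound 3 `CCCCCCCCCCCC[C@@H](O)[C@H]1CC[C@H]([C@H](O)CCCCCCCCCCNC(=O)c2cncs2)O1` gives 100000 nM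

Compound 3 has the highest number of the three, at 100000 nM, and so the weakest inhibition of growth. The next molecule, compound 4 `CCCCCCCCCCCC[C@@H](O)[C@H]1CC[C@H]([C@H](O)CCCCCCCCCCNC(=O)c2ccnn2C)O1`, keeps the shared core and chain and differs as follows: 1-methyl-1H-pyrazol-5-yl in place of 1,3-thiazol-5-yl on a carbonyl carbon. In short, 1-methyl-1H-pyrazol-5-yl stands in place of 1,3-thiazol-5-yl on a carbonyl carbon.

Three measured ring swaps at this same place bear on the change. They are a 13-fold higher number from compound 1 to compound 2 (1.12 log units; beyond the scatter), a 78-fold higher number from compound 1 to compound 3 (1.89 log units; beyond the scatter) and a 5.9-fold higher number from compound 2 to compound 3 (0.77 log units; beyond the scatter). Swaps here have therefore never stayed within the scatter, and their sizes run from modest to large. None of them involves a pyrazole, so the direction is uncertain. Still, compound 3 sits at the top of the range, and compound 2 lies below it by a 5.9-fold higher number from compound 2 to compound 3 (0.77 log units; beyond the scatter), so a modest fall is the likelier outcome. The expected change is a 3.3-fold lower number from compound 3 to compound 4 (0.52 log units; beyond the scatter). For compound 4 the estimated value is 30000 nM, with an expected range from 6000 nM to 100000 nM.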

Compound 4, concentration for 50% growth inhibition: 10 nM
Compound 4: the middle estimate sits 3000-fold (3.48 log units) above what was measured; measured number below the stated range.
By their numbers in this assay, from the lowest: compound 4; then compound 1; then compound 2; then compound 3.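

In this assay, the step of a 10000-fold lower number from compound 3 to compound 4 (4.00 log units; beyond the scatter) is the largest seen at this place on the carbonyl carbon, and it shows that the ring here can move the value much further than the earlier swaps did. The 1-methyl-1H-pyrazol-5-yl ring also outdoes the other two rings, with a 1700-fold lower number from compound 2 to compound 4 (3.23 log units; beyond the scatter) and a 130-fold lower number from compound 1 to compound 4 (2.11 log units; beyond the scatter) on the same read-out, which makes compound 4 the most potent of the four and takes the lead from thiophen-2-yl. No measurement offered here accounts for so wide a gap between 1,3-thiazol-5-yl and 1-methyl-1H-pyrazol-5-yl, although each is a five-membered aromatic ring with 2 hetero atoms.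

Still open, from the compounds shown here alone, is what the methyl group on the pyrazole contributes, which a 1H-pyrazol-5-yl or 1-ethyl-1H-pyrazol-5-yl ring would test. Also open, going by these compounds, is whether the result depends on the pyrazole itself, which a 1-methyl-1H-imidazol-5-yl ring would test.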